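Reversing a Ring Swap at the Aryl Amine Position

A few compounds are considered here, and "the series" means these few. Any claim that something is new, unique, unknown or untested is made for them only; others in the source may bear on it.

Measured compounds:
compound 1, `CN(C[C@H]1Cc2c(cccc2N2C[C@H]3CNC[C@H]3C2)CN1)[C@H]1CCCc2cccnc21` — 10.3 nM
compound 2, `CN(C[C@H]1Cc2c(cccc2N[C@H]2CC[C@H](N)CC2)CN1)[C@H]1CCCc2cccnc21` — 755 nM

Of the compounds shown here, two have been measured in a functional assay on CCRF-CEM cells for antagonist activity at C-X-C chemokine receptor type 4 (Homo sapiens), read by calcium flux, with stated times of 25 min and 90 s; on this read-out lower numbers stand for stronger inhibition and higher numbers for weaker inhibition. Compound 1 gives 10.3 nM, and compound 2 gives 755 nM. Among the measured compounds shown here, compound 2 therefore stands with the highest number of the two, and its only neighbour is compound 1, reached by a single change: a 73-fold higher number from compound 1 to compound 2 (1.87 log units; beyond the scatter).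

Compound 3, `CN1C[C@@H]2CN(c3cccc4c3C[C@H](CN(C)[C@H]3CCCc5cccnc53)NC4)C[C@@H]2C1`, is not yet measured. It differs from compound 2 as follows: a group of 9 heavy atoms (7 carbon, 2 nitrogen; 2 five-membered non-aromatic rings with 1 hetero atom each) in place of a group of 8 heavy atoms (6 carbon, 2 nitrogen; one six-membered non-aromatic ring of carbon only), on an aromatic carbon. The group that enters is the same bicyclic system carried by compound 1, now bearing a methyl on its ring nitrogen in place of the hydrogen-bond donor.

For the measured compounds named here, the one measured step that bears on this change is the step from compound 1 to compound 2, which was large. Going by the values given here, compound 3 essentially undoes that step, and the added methyl is a small alteration with no measured precedent here. A large decrease is therefore expected in this assay, close in size to the reverse of a 73-fold higher number from compound 1 to compound 2 (1.87 log units; beyond the scatter).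

The estimate for compound 3 is 15 nM, within 4 nM to 60 nM, which is expected to correspond to a 50-fold lower number from compound 2 to compound 3 (1.70 log units; beyond the scatter).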

Compound 3, half-maximal inhibitory concentration: 9.56 nM
Compound 3: middle estimate off by 1.6-fold (0.20 log units), on the high side; low and high end bracket the measured number.
By their numbers in this assay, from the lowest: compounds 3 and 1 (each within the scatter of the next); then compound 2.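

In this assay, among the compounds shown here, the step back to the bicyclic group with two five-membered rings on the aromatic carbon recovers nearly all that the (4-aminocyclohexyl)amino group had lost (a 79-fold lower number from compound 2 to compound 3 (1.90 log units; beyond the scatter)), which shows that this difference is not confined to the single pair of compounds measured earlier. Methyl in place of hydrogen on the ring nitrogen leaves the number within the scatter (a 1.1-fold lower number from compound 1 to compound 3 (0.03 log units; within the scatter)), so in this pair the entering group keeps its place in the read-out with 0 hydrogen-bond donors. The numbers alone offer no measured basis for explaining why the two groups on this aromatic carbon differ so widely.

The compounds shown leave open whether an ethyl, an acetyl or a benzyl group on the same ring nitrogen would stay within the scatter as methyl does. They also leave open whether a simpler ring such as piperazine or pyrrolidine on the aromatic carbon would match the bicyclic group, and whether the large step follows the carbocyclic ring of the (4-aminocyclohexyl)amino group or its primary amine.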